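Methyl in place of fluoro: expectation for compound 4

The source may hold more compounds than are shown below. What is called first, only, known or untested is meant among the compounds shown, and "the series" means these compounds.

Compound 3 `Cc1ccc(OCC(=O)NNC(=O)c2cc3ccccc3oc2=O)c(C(=O)c2ccc(F)cc2)c1` holds the second highest of the three numbers in a functional assay on DLA cells (Mus musculus) for cytotoxicity, read by MTT assay, with a stated time of 48 h (a higher number here means a weaker inhibitor, a lower number a stronger inhibitor), where compound 3 gives 43400 nM. Compound 1 `Cc1ccc(OCC(=O)NNC(=O)c2cc3ccccc3oc2=O)c(C(=O)c2ccccc2Br)c1` gives 10000 nM, and compound 2 `Cc1ccc(OCC(=O)NNC(=O)c2cc3ccccc3oc2=O)c(C(=O)c2ccc(Br)cc2)c1` gives 92200 nM. The move to compound 4 `Cc1ccc(C(=O)c2cc(C)ccc2OCC(=O)NNC(=O)c2cc3ccccc3oc2=O)cc1` is methyl in place of fluoro on an aromatic carbon. Within the data shown here, no measured step swaps fluoro for methyl. The comparisons that bear on it are a 2.1-fold lower number from compound 2 to compound 3 (0.33 log units; beyond the scatter) and a 4.3-fold higher number from compound 1 to compound 3 (0.64 log units; beyond the scatter), together with a 9.2-fold higher number from compound 1 to compound 2 (0.96 log units; beyond the scatter); all are modest and all sit beyond the scatter. A change of the group on this ring has so far shifted the number modestly, so a modest step is expected in this assay, probably toward a somewhat higher number, though the direction is uncertain. Compound 4 is therefore estimated at 55000 nM, within 20000 nM to 150000 nM. The expected step is a 1.3-fold higher number from compound 3 to compound 4 (0.10 log units; within the scatter).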

Compound 4, half-maximal inhibitory concentration: 84600 nM
Estimate against measurement, compound 4: 1.5-fold (0.19 log units) below, within the range that was stated.
By their numbers in this assay, from the lowest: compound 1; then compounds 3, 4 and 2 (each within the scatter of the next, the first and the last beyond it).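

With 4-methylphenyl, a 1.9-fold higher number from compound 3 to compound 4 (0.29 log units; within the scatter) and a 1.1-fold lower number from compound 2 to compound 4 (0.04 log units; within the scatter) both lie within the scatter in this assay, so methyl on this carbon is not separated from fluoro or from bromo, although those two are separated from each other. Among these compounds, the one step beyond the scatter is an 8.5-fold higher number from compound 1 to compound 4 (0.93 log units; beyond the scatter), so 2-bromophenyl again stands apart, as it did from the 4-bromophenyl and 4-fluorophenyl compounds. Nothing available explains these steps.

Still open, going by these compounds, is whether an amine or a carboxylic acid on this carbon would give a step beyond the scatter from methyl, and whether 2-methylphenyl would give a number like that of compound 1.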